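Removing the cyclohexyl group: effect on tolerated concentration

This account rests on a few compounds, and the source may have more. Where it says the series, first, only, none or still open, it means among the compounds named here.

Measured in an ADME assay on MDBK cells (Bos taurus) for cytotoxicity, read by MTT assay, with a stated time of 96 h; a higher number here means that more compound is tolerated, a lower number that less compound is tolerated:
compound 1 `CC(=O)c1ccc2[nH]c(-c3ccc(C(F)(F)F)cc3)nc2c1` — a limit of the assay, > 100000 nM
compound 2 `CC(=O)c1ccc2c(c1)nc(-c1ccc(C(F)(F)F)cc1)n2C1CCCCC1` — 52000 nM
compound 3 `CC(=O)c1ccc2c(c1)nc(-c1ccoc1)n2C1CCCCC1` — a limit of the assay, > 100000 nM

The value for compound 1 is a limit, not a number. The value for compound 3 is likewise a limit. Between compound 2 and compound 1 the change is hydrogen in place of cyclohexyl on an aromatic nitrogen; the step measured is an at least 1.9-fold higher number from compound 2 to compound 1 (0.28 log units; that floor lies within the scatter), and its floor is set by the limit of > 100000 nM in this assay, at which 2 of the 3 values shown sit. How the core of compound 2 and the core of compound 3 differ is not broken down here.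

Compound 4 `CC(=O)c1ccc2[nH]c(-c3ccoc3)nc2c1` is not yet measured. It arises from compound 3 by hydrogen in place of cyclohexyl on an aromatic nitrogen. This is the same kind of change as that from compound 2 to compound 1, though not the same: in compound 3 the ring nitrogen sits next to the ring atom that bears a furan-3-yl group, whereas in compound 2 that ring atom bears a large group. In this assay the step from compound 3 to compound 4 is expected to be a step that the limit leaves unreadable from compound 3 to compound 4, resting on an at least 1.9-fold higher number from compound 2 to compound 1 (0.28 log units; that floor lies within the scatter) and on compound 3 already sitting at the limit of > 100000 nM in this assay, at which 2 of the 3 values shown sit. Compound 4 is therefore estimated at 120000 nM, between 60000 nM and 250000 nM, most probably reported again only as a limit.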

Compound 4, half-maximal cytotoxic concentration: >= 100000 nM
Compound 4 ended at the assay's limit; the forecaster's own chance of this, stated with the estimate: 80%; the middle value does not contradict the limit.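

Compound 3 and compound 4 both stand only at limits in this assay, so the step between them, hydrogen in place of cyclohexyl on an aromatic nitrogen, cannot be read. The compounds shown leave open whether this change shifts the tolerated concentration at all when the furan-3-yl group is present.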